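A few compounds are considered here, and "the series" means these few. Any claim that something is new, unique, unknown or untested is made for them only; others in the source may bear on it.

Working notes on the series. The shared core, a sulfonamide on a piperidine bearing an acyl group, is held constant; the acyl group varies. Compound 1 `CN(C)CC(=O)N1CCC(NS(=O)(=O)c2cc(S(=O)(=O)c3ccccc3)ccc2C(F)(F)F)CC1` gives 300 nM in an assay on isolated protein for binding affinity to secreted frizzled-related protein 1 (Homo sapiens), read by fluorescence; a higher number here means a weaker inhibitor, a lower number a stronger inhibitor. Compound 2 `O=C(CN1CCCC1)N1CCC(NS(=O)(=O)c2cc(S(=O)(=O)c3ccccc3)ccc2C(F)(F)F)CC1` gives 110 nM, and the step of a 2.7-fold lower number from compound 1 to compound 2 (0.44 log units; beyond the scatter). Compound 3 `CC(C)(C)OC(=O)N1CCC[C@H]1C(=O)N1CCC(NS(=O)(=O)c2cc(S(=O)(=O)c3ccccc3)ccc2C(F)(F)F)CC1` gives 60 nM, the lowest of the three numbers; against compound 1 the step is a 5.0-fold lower number from compound 1 to compound 3 (0.70 log units; beyond the scatter), while against compound 2 it is a 1.8-fold lower number from compound 2 to compound 3 (0.26 log units; within the scatter), so compound 3 and compound 2 cannot be ordered.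

The next step keeps the pyrrolidine of compound 3 and changes only the group on its nitrogen: compound 4 `CN(C)CC(=O)N1CCC[C@H]1C(=O)N1CCC(NS(=O)(=O)c2cc(S(=O)(=O)c3ccccc3)ccc2C(F)(F)F)CC1` differs from compound 3 by (dimethylamino)methyl in place of tert-butoxy on a carbonyl carbon. Among the measured compounds shown here, no measured pair shows this exact change. The nearest information is compound 1, where a (dimethylamino)methyl carbonyl sits on the core directly and gives the highest number of the three, and the steps from compound 1 to compound 2 and from compound 1 to compound 3, both modest. A modest rise in the number is therefore expected rather than none, though with little support. Compound 4 is estimated at 130 nM, range 40 nM to 400 nM. The expected step is a 2.2-fold higher number from compound 3 to compound 4 (0.34 log units; beyond the scatter).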

Compound 4, half-maximal inhibitory concentration: 90 nM
Beside the measured number, compound 4's estimate is 1.4-fold (0.16 log units) above it, within the range that was stated.
By their numbers in this assay, from the lowest: compounds 3, 4 and 2 (each within the scatter of the next); then compound 1.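

At the carbonyl carbon whose other neighbour is an amide-type nitrogen in a ring, (dimethylamino)methyl in place of tert-butoxy gives a 1.5-fold higher number from compound 3 to compound 4 (0.18 log units; within the scatter) in this assay, so the two groups cannot be told apart here and the low number of compound 3 does not depend on keeping the tert-butoxycarbonyl group. The (dimethylamino)methyl carbonyl group gave the highest number when placed directly on the core in compound 1, yet adding the pyrrolidin-2-yl unit ahead of it gives a 3.3-fold lower number from compound 1 to compound 4 (0.52 log units; beyond the scatter) and leaves the comparison with the pyrrolidin-1-yl compound as a 1.2-fold lower number from compound 2 to compound 4 (0.09 log units; within the scatter) in this assay, so compound 4 joins compound 2 and compound 3 as separated from compound 1 but not from each other. No measurement shown here bears on the reason for these numbers.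

Still open, from the compounds shown here alone, is whether a free secondary amine on the pyrrolidine nitrogen, or a carboxylic acid or a longer chain on this carbonyl carbon, would stay in the same range. Compound 3 and compound 4 also share one configuration at the pyrrolidin-2-yl carbon, which leaves the opposite configuration an open question.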